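The source may hold more compounds than are shown below. What is called first, only, known or untested is meant among the compounds shown, and "the series" means these compounds.

Measured in a functional assay on K562 cells (Homo sapiens) for cytotoxicity, read by MTT assay, with a stated time of 72 h; on this read-out higher numbers stand for weaker inhibition and lower numbers for stronger inhibition:

Compound 1 `C=C1CC[C@H]2C(C)(C)CCC[C@]2(C)[C@H]1CCC(C)CC(=O)O`: > 200000 nM
Compound 2 `Cc1ccc(/C=C2\CC[C@H]3C(C)(C)CCC[C@]3(C)[C@H]2CCC(C)CC(=O)O)cc1`: > 200000 nM

Compound 2 gives no numerical value in this assay, and its > 200000 nM is a limit of the assay. Compound 1 is also reported only as a limit, so the two results together stand at the limit of > 200000 nM in this assay, at which 2 of the 2 values shown sit.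

Compound 3 `CC(CC[C@H]1/C(=C/c2ccc(F)cc2)CC[C@H]2C(C)(C)CCC[C@]12C)CC(=O)O` differs from compound 2 in one place: fluoro in place of methyl on an aromatic carbon. This puts fluoro in place of methyl on an aromatic carbon, para to a large group, changing 4-methylphenyl to 4-fluorophenyl. Among the measured compounds shown here, no measured pair shows the size of this change. The expectation therefore rests on compound 2 at > 200000 nM, and no shift beyond the scatter is expected in this assay. The estimated step is a number no higher from compound 2 to compound 3 (the limit leaves the size open). A further limit is the most likely report. For compound 3 the estimated value is 200000 nM, with an expected range from 80000 nM to 400000 nM.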

Compound 3, half-maximal inhibitory concentration: > 200000 nM
Compound 3: only a limit was reported; the forecaster's own chance of this, stated with the estimate: 75%; the middle value sits exactly at the limit.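

Compound 3 is reported in this assay only as a limit, > 200000 nM. No step can therefore be read between compound 2 and compound 3: the limit of > 200000 nM in this assay, at which 3 of the 3 values shown sit.

The compounds shown leave open whether 4-methylphenyl and 4-fluorophenyl differ at all in this read-out.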